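The compounds below may be only part of what the source reports. "The series", "measured", "known", "first", "only" and "open" are said of these compounds alone.

Two compounds have been examined in an assay on isolated protein for activation of cGMP-dependent protein kinase 1 (Homo sapiens), read by ADP-Glo, with stated times of 120 min and 40 min (a lower number here means that less compound is needed, a higher number that more compound is needed for the effect), so far. Compound 1, whose structure is `CN1CCC[C@H](OCc2cc(Cl)cc(Cl)c2)[C@@H]1c1ccccc1`, gives only a limit in this assay: for compound 1 the reading is > 200000 nM, which is the point at which the measurement stops rather than a number. One of the two readings to date sits at the limit of > 200000 nM in this assay, at which 1 of the 2 values shown sits. Compound 2, with the structure `COC(=O)Nn1c(C[C@H]2CCC[C@H](OCc3cc(C(F)(F)F)cc(C(F)(F)F)c3)[C@@H]2c2ccccc2)n[nH]c1=O`, is a larger molecule built on the same core; in this assay compound 2 gives 4500 nM.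

The step now followed leads from compound 1 to compound 3, whose structure is `O=C(O)c1ccc(CN2CCC[C@H](OCc3cc(Cl)cc(Cl)c3)[C@@H]2c2ccccc2)cc1`. The change is 4-carboxyphenyl in place of hydrogen on a saturated chain carbon bound to an amine nitrogen in a ring. Compound 2 shows that a reading well inside the measurable range can be reached from this core, but it differs from compound 1 in several places at once, so nothing has yet been measured that isolates the effect of a single change.

Compound 3 is expected to move into the measurable range, with an estimated step of an at least 4.0-fold lower number from compound 1 to compound 3 (0.60 log units; beyond the scatter). The expected value for compound 3 is 50000 nM, in a range from 10000 nM to 200000 nM.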

Compound 3, half-maximal effective concentration: 76000 nM
Compound 3: middle estimate off by 1.5-fold (0.18 log units), on the low side, and the stated range covers the measured number.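

For the compounds shown here, for the first time, a single change on the shared core can be read: with 4-carboxyphenyl in place of hydrogen on a saturated chain carbon bound to an amine nitrogen in a ring, this assay shows an at least 2.6-fold lower number from compound 1 to compound 3 (0.42 log units; beyond the scatter). Read one bond further out, this is methyl to 4-carboxybenzyl, so a substantial addition at this place is compatible with a measurable reading, and compound 3 gives 76000 nM. The size of the step is only a lower bound, because the reading for compound 1 is a limit of the assay and not a number: the limit of > 200000 nM in this assay, at which 1 of the 3 values shown sits.

On these data alone, it remains open whether the gain depends on the carboxyl group or on the added aromatic ring, a question that a plain benzyl group, a methyl ester or a primary amide at this place could help to separate. Compound 2 differs from compound 3 in several places, so the two readings cannot show which of those differences matter or whether the changes in compound 2 could add to this one.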